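Swapping One Five-Membered Ring for Another on a Shared Core

The source may hold more compounds than are shown below. What is called first, only, known or untested is meant among the compounds shown, and "the series" means these compounds.

Of the compounds shown here, three built on one shared core have been measured. Compound 1 `CCOC(=O)c1cc2c(CN3CCCC3)c(O)c(OC)cc2nc1C[S+]([O-])c1ccc(F)c(F)c1` gives 16.5 uM in an ADME assay on HepG2 2.2.15 cells (Homo sapiens) for cytotoxicity, read by MTT assay, with a stated time of 9 days (a lower number here means that less compound is tolerated, a higher number that more compound is tolerated), the second highest of the three numbers. Compound 2 `CCOC(=O)c1cc2c(CN3CCCC3)c(O)c(OC)cc2nc1C[S+]([O-])c1ccccn1` gives 9.4 uM, and compound 3 `CCOC(=O)c1cc2c(CN3CCCC3)c(O)c(OC)cc2nc1CSc1ccccn1` gives 17.5 uM. The steps of a 1.8-fold lower number from compound 1 to compound 2 (0.24 log units; within the scatter), a 1.1-fold higher number from compound 1 to compound 3 (0.03 log units; within the scatter) and a 1.9-fold higher number from compound 2 to compound 3 (0.27 log units; within the scatter) all stay within the scatter. Each of those steps alters the group on the sulfur, so none bears directly on the change to compound 4 `CCOC(=O)c1cc2c(Cn3ccnc3)c(O)c(OC)cc2nc1C[S+]([O-])c1ccc(F)c(F)c1`, which is 1H-imidazol-1-yl in place of pyrrolidin-1-yl on a saturated chain carbon bound to an aromatic carbon. For the measured compounds named here, with no measured step on this kind of change, the narrow spread of the three numbers is the only guide, and no step beyond the scatter is expected. Compound 4 is therefore estimated at 15 uM, between 6 uM and 40 uM. The expected step is a 1.1-fold lower number from compound 1 to compound 4 (0.04 log units; within the scatter).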

Compound 4, half-maximal toxic concentration: 90.8 uM
The estimate for compound 4 lay 6.1-fold (0.78 log units) below the measured number; measured number outside the range, above it.
By their numbers in this assay, from the lowest: compounds 2, 1 and 3 (each within the scatter of the next); then compound 4.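

In this assay, 1H-imidazol-1-yl in place of pyrrolidin-1-yl on a saturated chain carbon bound to an aromatic carbon gives a 5.5-fold higher number from compound 1 to compound 4 (0.74 log units; beyond the scatter), so more compound is tolerated. For the compounds shown here, this is the first step here that lies beyond the scatter, as all three changes around the sulfur stayed within it. No measurement at hand bears on the reason for this step.

On these data alone, it remains open whether the same change holds with pyridin-2-yl on the sulfur, as in compound 2. As far as these compounds go, how a 1H-pyrazol-1-yl ring or an open-chain dimethylamino group would read in this place is also open.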